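Changing the Aryl Group on an Aromatic Nitrogen

This account rests on a few compounds, and the source may have more. Where it says the series, first, only, none or still open, it means among the compounds named here.

Compound 1 `N#CC1=C(N)Oc2c(N)cc3nc4ccccc4nc3c2C12C(=O)N(Cc1cnnn1-c1ccccc1Br)c1ccccc12`: 12400 nM
Compound 2 `COc1ccc(-n2nncc2CN2C(=O)C3(C(C#N)=C(N)Oc4c(N)cc5nc6ccccc6nc5c43)c3ccccc32)cc1`: > 50000 nM
Compound 3 `CCOc1ccc(-n2nncc2CN2C(=O)C3(C(C#N)=C(N)Oc4c(N)cc5nc6ccccc6nc5c43)c3ccccc32)cc1`: > 50000 nM

In a functional assay on HCT-116 cells (Homo sapiens) for antiproliferative activity, read by MTT assay, with a stated time of 48 h (a lower number here means a stronger inhibitor, a higher number a weaker inhibitor), compound 1 gives 12400 nM. Compound 2 gives only a limit of the assay, > 50000 nM. Compound 3 likewise gives only a limit, > 50000 nM, so compound 3 stands at the weak end of what has been measured, sharing the limit of > 50000 nM in this assay, at which 2 of the 3 values shown sit, with compound 2. The two steps from compound 1, an at least 4.0-fold higher number from compound 1 to compound 2 (0.60 log units; beyond the scatter) and an at least 4.0-fold higher number from compound 1 to compound 3 (0.60 log units; beyond the scatter), show that a 4-alkoxyphenyl on the aromatic nitrogen weakens the compound relative to 2-bromophenyl, while a step that the two limits leave unreadable from compound 2 to compound 3 cannot be read.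

Compound 4 `Cc1ccc(-n2nncc2CN2C(=O)C3(C(C#N)=C(N)Oc4c(N)cc5nc6ccccc6nc5c43)c3ccccc32)cc1Cl` differs from compound 3 by 3-chloro-4-methylphenyl in place of 4-ethoxyphenyl on an aromatic nitrogen. Among the compounds with values here, the step that leads to compound 4 removes the alkoxy group, which the two readable steps associate with the weakest values, but no measured pair tests a 3-chloro-4-methylphenyl, so the expectation is loose. Compound 4 is expected to land at 30000 nM, between 8000 nM and 50000 nM, which would mean an expected step of an at least 1.6-fold lower number from compound 3 to compound 4 (0.22 log units; that floor lies within the scatter) in this assay.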

Compound 4, half-maximal inhibitory concentration: > 50000 nM
Compound 4: no number, only a limit (the forecaster's own chance of this, stated with the estimate: 50%); at least 1.6-fold (0.22 log units) between middle value and limit.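

Taking out the alkoxy group did not recover activity: the loss relative to 2-bromophenyl also appears with 3-chloro-4-methylphenyl on this aromatic nitrogen, with an at least 4.0-fold higher number from compound 1 to compound 4 (0.60 log units; beyond the scatter). Among the four aryl groups shown, the loss is therefore not confined to 4-alkoxyphenyl, and only compound 1, with its 2-bromophenyl, gives a number, 12400 nM. Compound 4, like compound 2 and compound 3, gives a limit of the assay and not a number, so the steps among these three cannot be read: the limit of > 50000 nM in this assay, at which 3 of the 4 values shown sit.

The compounds shown leave open whether a plain phenyl, a 2-chlorophenyl or a 4-bromophenyl on the same nitrogen would give a number in this assay. They also leave open whether compound 2, compound 3 and compound 4 differ from one another at all.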